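One Added Methyl on a Butyl Chain

This account rests on a few compounds, and the source may have more. Where it says the series, first, only, none or still open, it means among the compounds named here.

Compound 1 `CC(C)(C)CCOc1cccc(O)c1C(=O)/C=C/c1ccc(O)cc1` in a functional assay on HCT-15 cells (Homo sapiens) for antiproliferative activity, read by sulforhodamine B assay; a higher number here means a weaker inhibitor of growth, a lower number a stronger inhibitor of growth: 3430 nM
Compound 2 `CCCCOc1cccc(O)c1C(=O)/C=C/c1ccc(O)cc1` in this assay: > 30000 nM, a limit of the assay

Compound 2 gives no number, only a limit, and stands at the limit of > 30000 nM in this assay, at which 1 of the 2 values shown sits. Compound 3 `CC(C)CCOc1cccc(O)c1C(=O)/C=C/c1ccc(O)cc1` differs from compound 2 by methyl in place of hydrogen on a saturated chain carbon bound to two saturated chain carbons, the same difference reading as butyl to isopentyl. Going by the values given here, one measured step bears on this change, an at least 8.7-fold higher number from compound 1 to compound 2 (0.94 log units; beyond the scatter). Its true size is not known, since one end of it is a limit. Structurally, compound 3 falls between compound 2 and compound 1, so part of that step is expected to return, moving towards a lower number in this assay, a stronger inhibition of growth. This rests on a single pair, and compound 3 may yet remain at the limit. The expected size of the change is an at least 3.0-fold lower number from compound 2 to compound 3 (0.47 log units; beyond the scatter). For compound 3 the estimated value is 10000 nM, with an expected range from 3500 nM to 30000 nM.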

Compound 3, concentration for 50% growth inhibition: 10600 nM
The estimate for compound 3 lay 1.1-fold (0.03 log units) below the measured number; the measured number falls inside the stated range.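

In this assay, a single methyl in place of hydrogen on a saturated chain carbon bound to two saturated chain carbons, the change from butyl to isopentyl, is enough to bring the compound back from the limit, with an at least 2.8-fold lower number from compound 2 to compound 3 (0.45 log units; beyond the scatter). Isopentyl does not recover everything, since hydrogen in place of methyl on a saturated chain carbon bound to three saturated chain carbons gives a 3.1-fold higher number from compound 1 to compound 3 (0.49 log units; beyond the scatter), so the earlier single step now divides into two parts, each with a reading beyond the scatter. Compound 2 gives only a limit of the assay, so the true size of the first part, and therefore how the whole step divides, stays unknown: the limit of > 30000 nM in this assay, at which 1 of the 3 values shown sits.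

The compounds shown leave open whether the gain follows the branching of the chain or simply the added carbon, a question that a straight pentyl chain on the same core would address. They also leave open whether a polar end group on the chain, such as an amine, would be tolerated at this position.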